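The source may report more compounds than this note shows. Statements on the series, on what has been measured and on what is new or still open speak of the compounds shown alone.

Measured compounds:
compound 1 `O=c1[nH]cnc2c1c(-c1ccoc1)cn2[C@@H]1O[C@H](CO)[C@@H](O)[C@H]1O` with > 20000 nM in a functional assay on HeLa S3 cells (Homo sapiens) for antiproliferative activity, read by XTT assay, with a stated time of 72 h; on this read-out lower numbers stand for stronger inhibition and higher numbers for weaker inhibition
compound 2 `O=c1[nH]cnc2c1c(-c1cccs1)cn2[C@@H]1O[C@H](CO)[C@@H](O)[C@H]1O` with > 20000 nM in this assay

Compound 1 stands only at a limit in this assay. Compound 2 likewise gives only a limit there. Both values sit at the same limit, as the limit of > 20000 nM in this assay, at which 2 of the 2 values shown sit, records, so the change of thiophen-2-yl in place of furan-3-yl on an aromatic carbon yields a step that the two limits leave unreadable from compound 1 to compound 2, a step whose size cannot be read.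

Compound 3 `Nc1nc2c(c(-c3ccoc3)cn2[C@@H]2O[C@H](CO)[C@@H](O)[C@H]2O)c(=O)[nH]1` differs from compound 1 by amino in place of hydrogen on an aromatic carbon. No measured step touches this change: the single step shown is unreadable, and neither measured compound carries an amino group at this place. Nothing in the measurements therefore points toward a stronger or weaker result for compound 3 in this assay, and the most that can be said is that both measured compounds remained at the limit.

Compound 3 is thus expected to give about 30000 nM in this assay, with a range from 6000 nM to 150000 nM, most likely again reported as a limit rather than a number. This corresponds to an expected step that the limit leaves unreadable from compound 1 to compound 3 from compound 1 to compound 3.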

Compound 3, half-maximal inhibitory concentration: 10700 nM
Beside the measured number, compound 3's estimate is 2.8-fold (0.45 log units) above it; the range from low to high includes it.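

Of the compounds shown in this assay, only compound 3 gives a number rather than a limit, which makes this position, on an aromatic carbon between two ring nitrogen atoms, the first place in the set where a change shows up as a readable value. Amino in place of hydrogen there yields an at least 1.8-fold lower number from compound 1 to compound 3 (0.27 log units; that floor lies within the scatter), and this is a floor rather than a full size, so the true gap may be wider, but what can be read does not go beyond the scatter. The floor rests on the limit that still holds the other two compounds: the limit of > 20000 nM in this assay, at which 2 of the 3 values shown sit.

The compounds shown leave open whether the amino group would bring the thiophen-2-yl compound 2 to a readable number as well, or whether its effect is tied to the furan-3-yl group of compound 3. They also leave open what a methylamino or dimethylamino group, a methyl group or a chlorine atom on the same aromatic carbon would do in this assay, so it cannot yet be said whether the amino group itself is needed there.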